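Piperidine versus pyrrolidine thiosemicarbazides on A-375 cells

The source may report more compounds than this note shows. Statements on the series, on what has been measured and on what is new or still open speak of the compounds shown alone.

The series is read in a functional assay on A-375 cells (Homo sapiens) for cytotoxicity, read by MTT assay, with a stated time of 72 h, tested at 100 uM; a lower number here means less inhibition of growth, a higher number more inhibition of growth at the concentration tested. Compound 1 `N/C(=N\NC(=S)N1CCCCC1)c1ccccn1` gives 88.5% in this assay. Compound 2 `Cc1cccc(/C(N)=N/NC(=S)N2CCCCC2)n1` carries a methyl on the ring and gives 85.7%. Compound 3 `Cc1cccc(/C(N)=N/NC(=S)N2CCCC2)n1` differs from compound 2 as follows: pyrrolidin-1-yl in place of piperidin-1-yl on a thiocarbonyl carbon, and in this assay compound 3 gives 66.3%, the lowest of the three measured numbers. For the measured compounds named here, the step of a number 19.4 percentage points lower from compound 2 to compound 3 (beyond the scatter) is the only change beyond the scatter seen so far.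

The change from compound 2 to compound 1 is hydrogen in place of methyl on an aromatic carbon, and it made the step of a number 2.8 percentage points higher from compound 2 to compound 1 (within the scatter). Compound 4 `N/C(=N\NC(=S)N1CCCC1)c1ccccn1`, not yet measured, is reached from compound 3 by hydrogen in place of methyl on an aromatic carbon, with the place described in the same words, so it is the same change, made on the core of compound 3 rather than that of compound 2; the change occurs twice among these compounds.

Going by the values given here, with only one earlier instance, the step from compound 3 to compound 4 is expected to be a number 2.7 percentage points higher from compound 3 to compound 4 (within the scatter), resting on a number 2.8 percentage points higher from compound 2 to compound 1 (within the scatter) and on compound 3 at 66.3%. Compound 4 is therefore estimated at 69%, between 56% and 82%.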

Compound 4, percent growth inhibition at one concentration: 87.8%
Beside the measured number, compound 4's estimate is 18.8 percentage points below it; measured number above the stated range.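

The new step is a number 21.5 percentage points higher from compound 3 to compound 4 (beyond the scatter), so in this assay hydrogen in place of methyl on an aromatic carbon does not carry from one core to the other at a single size: the same change on two cores in this assay, a number 2.8 percentage points higher (within the scatter) from compound 2 to compound 1 and a number 21.5 percentage points higher (beyond the scatter) from compound 3 to compound 4, 18.7 percentage points apart, beyond the scatter of two such steps

Read along the other edge, pyrrolidin-1-yl in place of piperidin-1-yl gives a number 0.7 percentage points lower from compound 1 to compound 4 (within the scatter), and the size of that change also depends on the core: the same change on two cores in this assay, a number 19.4 percentage points lower (beyond the scatter) from compound 2 to compound 3 and a number 0.7 percentage points lower (within the scatter) from compound 1 to compound 4, 18.7 percentage points apart, beyond the scatter of two such steps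

Both gaps rest on the same four numbers and amount to one observation, which hangs on compound 3 alone; it shows that the two changes do not add up independently in this small set, but it does not show why, nor whether a repeat of compound 3 would hold.

The compounds shown leave open whether this dependence on the core extends to other amines on the thiocarbonyl carbon, such as morpholine or dimethylamine. Also open, from the compounds shown here alone, is how an ethyl group or a chlorine atom in place of the methyl would behave on either core.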